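Changing the pendant ring on a shared inhibitor core

The source may report more compounds than this note shows. Statements on the series, on what has been measured and on what is new or still open speak of the compounds shown alone.

Of the compounds shown here, three built on one shared core have been tested in an assay on isolated protein for inhibition of Leucine-rich repeat serine/threonine-protein kinase 2 (Homo sapiens), in the presence of a further agent that is not named here; on this read-out lower numbers stand for stronger inhibition and higher numbers for weaker inhibition. Compound 1 `COc1ccc(OC)c(Sc2ccc3nnc(-c4ccccn4)n3n2)c1` gives 496 nM. Compound 2 `COc1ccc(OC)c(Sc2ccc3nnc(-c4ccncc4)n3n2)c1` gives 349 nM, the lowest of the three numbers. Compound 3 `COc1ccc(OC)c(Sc2ccc3nnc(-c4cnccn4)n3n2)c1` gives 880 nM. The change a 1.4-fold lower number from compound 1 to compound 2 (0.15 log units; within the scatter) falls within the scatter, as does a 1.8-fold higher number from compound 1 to compound 3 (0.25 log units; within the scatter), while a 2.5-fold higher number from compound 2 to compound 3 (0.40 log units; beyond the scatter) is a modest step beyond it. Compound 2 thus stands at the low end, with compound 1 close to it and compound 3 somewhat higher.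

Compound 4 `COc1cncc(-c2nnc3ccc(Sc4cc(OC)ccc4OC)nn23)c1` has not yet been measured. It differs from compound 2 in one place: 5-methoxypyridin-3-yl in place of pyridin-4-yl on an aromatic carbon. The measured steps all exchange one six-membered ring carrying ring nitrogen for another at this same place, and the largest of them, a 2.5-fold higher number from compound 2 to compound 3 (0.40 log units; beyond the scatter), is only modest, while a 1.4-fold lower number from compound 1 to compound 2 (0.15 log units; within the scatter) stays within the scatter. Among the measured compounds shown here, the change to compound 4 alters where the ring nitrogen sits and adds a methoxy group, a combination none of the measured steps covers. On that basis only a small shift in this assay is expected, if any, with a slight lean toward a higher number, given that compound 2 holds 349 nM, the lowest of the three. For compound 4 the expected step is a 1.3-fold higher number from compound 2 to compound 4 (0.11 log units; within the scatter). Compound 4 is therefore estimated at 450 nM, within 180 nM to 1100 nM.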

Compound 4, half-maximal inhibitory concentration: 66 nM
For compound 4 the middle estimate is 6.8-fold (0.83 log units) above the measured one, and the stated range ends above it.
By their numbers in this assay, from the lowest: compound 4; then compounds 2, 1 and 3 (each within the scatter of the next, the first and the last beyond it).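

With 5-methoxypyridin-3-yl on the shared core, compound 4 is the strongest inhibitor of the four in this assay, showing a 5.3-fold lower number from compound 2 to compound 4 (0.72 log units; beyond the scatter), along with a 7.5-fold lower number from compound 1 to compound 4 (0.88 log units; beyond the scatter) and a 13-fold lower number from compound 3 to compound 4 (1.12 log units; beyond the scatter). Among the compounds shown here, the largest step among the earlier compounds was a 2.5-fold higher number from compound 2 to compound 3 (0.40 log units; beyond the scatter), so this position can respond much more strongly than those ring exchanges alone revealed. No information is available on why this group gives such a low number.

The change to compound 4 moves the ring nitrogen and adds a methoxy group at once, so the compounds shown cannot separate the contribution of the two, and a plain pyridin-3-yl ring would be needed to tell them apart. From the compounds shown here alone, it also remains open whether the gain would persist with an ethoxy group, an amine or a longer chain in place of the methoxy group, or whether it would carry over to other measures of inhibition beyond this single binding read-out.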